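The compounds below may be only part of what the source reports. "The series", "measured", "known", "first", "only" and "open" are said of these compounds alone.

Of the compounds shown here, three sharing one core have been measured in a functional assay on CHO cells for agonist activity at Alpha-2C adrenergic receptor (Homo sapiens); a lower number here means that less compound is needed, a higher number that more compound is needed for the effect. Compound 1 `CC(Oc1ccccc1C=O)C1=NCCN1` gives 100 nM, compound 2 `C=COc1ccccc1OC(C)C1=NCCN1` gives 631 nM, and compound 3 `Cc1cccc(C)c1OC(C)C1=NCCN1` gives 27.5 nM. Compound 2 therefore stands highest of the three numbers, meaning the most compound is needed; its nearest neighbour is compound 1 and its furthest is compound 3. Going by the values given here, the only measured step that ends at compound 2 is a 6.3-fold higher number from compound 1 to compound 2 (0.80 log units; beyond the scatter), a change at the same place on the ring that raised the number when vinyloxy replaced formyl.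

Compound 4 `CC(Oc1ccccc1OC1CC1)C1=NCCN1` differs from compound 2 in a single place: cyclopropyl in place of vinyl on an oxygen on an aromatic ring. Among the compounds with values here, no measured step in this set swaps vinyl for cyclopropyl, so the step from compound 1 to compound 2 bears only indirectly on it, by showing that this position tolerates a group on the ring oxygen. Both groups are small, carbon-only and without donors or acceptors, so the expected change in this assay is small, within the scatter or close to it, with a slight lean towards a lower number. The estimate for compound 4 is therefore 450 nM, with a range from 150 nM to 1300 nM, an expected step of a 1.4-fold lower number from compound 2 to compound 4 (0.15 log units; within the scatter).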

Compound 4, half-maximal effective concentration: 47.9 nM
The estimate for compound 4 lay 9.4-fold (0.97 log units) above the measured number; the measured number lies below the stated range.
By their numbers in this assay, from the lowest: compounds 3 and 4 (each within the scatter of the next); then compound 1; then compound 2.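

Going by these compounds alone, the group on the ring oxygen matters far more in this assay than the earlier compounds could show: the step of a 13-fold lower number from compound 2 to compound 4 (1.12 log units; beyond the scatter) exchanges vinyl for cyclopropyl, and neither group carries a hydrogen-bond donor or acceptor. Replacing formyl at this place can also move the number in either direction, since vinyloxy gives a 6.3-fold higher number from compound 1 to compound 2 (0.80 log units; beyond the scatter) while cyclopropyloxy gives a 2.1-fold lower number from compound 1 to compound 4 (0.32 log units; beyond the scatter), so the outcome depends on which group replaces formyl and not simply on its removal. Nothing available here explains why this small exchange has such a large effect.

The compounds shown leave open whether the step follows from the three-membered ring, the additional carbon or the loss of the double bond, and an ethyl or isopropyl group on the same oxygen would help to tell these apart. Going by these compounds, it also remains open how this position would respond to a longer chain, such as butyl, or to a group of a different kind, such as an amine or a carboxylic acid.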